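This account rests on a few compounds, and the source may have more. Where it says the series, first, only, none or still open, it means among the compounds named here.

Of the compounds shown here, three have been tested in a functional assay on TK-10 cells (Homo sapiens) for cytotoxicity, read by sulforhodamine B assay, with a stated time of 48 h; on this read-out higher numbers stand for weaker inhibition of growth and lower numbers for stronger inhibition of growth. Compound 1 `ClCc1ccc(Cn2cnc3c(Cl)ncnc32)cc1` gives 1090 nM in this assay. Compound 2 `ClCc1ccccc1Cn1cnc2c(Cl)nc(Cl)nc21` gives 1450 nM in this assay. Compound 3 `ClCc1cccc(Cn2cnc3c(Cl)ncnc32)c1` gives 4570 nM in this assay, the highest of the three numbers, standing beyond the scatter above both compound 2 and compound 1. Among the compounds with values here, none of these three differ from one another in a single place, so no clean step between measured compounds can be drawn.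

Compound 4 `ClCc1cccc(Cn2cnc3c(Cl)nc(Cl)nc32)c1` keeps the whole of compound 3 apart from one change: chloro in place of hydrogen on an aromatic carbon. Compound 2 carries the same doubly chlorinated core, but its benzyl side chain is not that of compound 3; the value of compound 2, 1450 nM, only hints that a second chloro on the core is compatible with growth inhibition in this range. With no direct comparison available, a modest lowering of the number is expected, though a change that stays within the scatter is also plausible, and the step from compound 3 to compound 4 is estimated at a 1.8-fold lower number from compound 3 to compound 4 (0.26 log units; within the scatter). Compound 4 is therefore expected to give about 2500 nM in this assay, with a plausible range from 900 nM to 7000 nM.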

Compound 4, concentration for 50% growth inhibition: 1730 nM
Estimate against measurement, compound 4: 1.4-fold (0.16 log units) above; the range from low to high includes it.
By their numbers in this assay, from the lowest: compounds 1, 2 and 4 (each within the scatter of the next); then compound 3.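

Within the data shown here, compound 3 and compound 4 give the first clean single-place comparison in this assay: chloro in place of hydrogen on the aromatic carbon between two ring nitrogen atoms gives a 2.6-fold lower number from compound 3 to compound 4 (0.42 log units; beyond the scatter). This position on the shared core therefore accepts a chloro group, and in this pair the change goes with stronger inhibition of growth, by a step beyond the usual scatter. Nothing measured here accounts for that step.

From the compounds shown here alone, whether an amine, a methoxy group or a longer chain at this same position would give a similar number remains open. Going by these compounds, it is also open whether the same step would appear on compound 1, which carries hydrogen at this position.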